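The source may hold more compounds than are shown below. What is called first, only, known or untested is meant among the compounds shown, and "the series" means these compounds.

Measured compounds:
compound 1, `O=C1C=C(Nc2ccccc2)C(=O)c2c1nc1n2[C@H]2OC[C@@H](O)[C@H]2OC1`, 4970 nM
compound 2, `O=C1C(NC2CCCC2)=CC(=O)c2c1nc1n2[C@H]2OC[C@@H](O)[C@H]2OC1`, > 16000 nM

Working notes on the series. The read-out is a functional assay on ECa-109 cells for inhibition, with ECa-109 cell line (Homo sapiens) as the target, read by sulforhodamine B assay; a lower number here means a stronger inhibitor, a higher number a weaker inhibitor. Compound 1 carries a phenylamino group on the shared core and gives 4970 nM. For compound 2, which carries a cyclopentylamino group on the same core, the assay returns only a limit, > 16000 nM, so no number is known for it; this is the limit of > 16000 nM in this assay, at which 1 of the 2 values shown sits. Compound 1 therefore has a measured value where compound 2 has none, and compound 2 stands at the weak end of what is shown.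

The unmeasured compound 3, `O=C1C(Nc2ccc(Br)cc2)=CC(=O)c2c1nc1n2[C@H]2OC[C@@H](O)[C@H]2OC1`, differs from compound 2 in one place: 4-bromophenyl in place of cyclopentyl on an amine nitrogen. With this change compound 3 returns to an aryl amine of the kind seen in compound 1, so a move away from the limit toward the value of compound 1 is expected, in the direction of stronger inhibition. The step of an at least 3.5-fold lower number from compound 2 to compound 3 (0.55 log units; beyond the scatter) is expected to be a sizable one. For compound 3 the estimate is 4500 nM, with a range from 1500 nM to 14000 nM.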

Compound 3, half-maximal inhibitory concentration: 1980 nM
Compound 3: the middle estimate sits 2.3-fold (0.36 log units) above what was measured; low and high end bracket the measured number.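

In this assay, among these compounds, 4-bromophenyl in place of cyclopentyl on an amine nitrogen gives an at least 8.0-fold lower number from compound 2 to compound 3 (0.90 log units; beyond the scatter), the only step that can be read at one place, and it shows that the group on this nitrogen moves the read-out beyond the scatter. The size of that step is only a lower bound, and compound 2 supplies a limit of the assay rather than a number: the limit of > 16000 nM in this assay, at which 1 of the 3 values shown sits. Among the compounds shown here, compound 3 thus gives the series a measured value with the amine in the arrangement of compound 2, whereas compound 1 differs from compound 3 in more than one place, so no step between those two is read.

The compounds shown do not separate the contribution of the aromatic ring from that of the bromine, a question that plain phenyl on this same nitrogen, with the arrangement of compound 3, would address. As far as these compounds go, how far the change extends also stays open for other groups here, such as 4-chlorophenyl, 4-methoxyphenyl, a pyridine ring or benzyl.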